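This account rests on a few compounds, and the source may have more. Where it says the series, first, only, none or still open, it means among the compounds named here.

Compound 1, `CC1(C)C[C@H](CN([C@H](CCC(F)(F)F)C(N)=O)S(=O)(=O)c2ccc(Cl)cc2)O1`, was tested in an ADME assay on MDCKII-LE cells (Canis lupus familiaris) for permeability, read by transwell migration, in the apical to basolateral direction (a higher number here means that the compound crosses the layer faster, a lower number that the compound crosses the layer more slowly), where compound 1 gives 18.1 10^-6 cm/s. Among the three measured compounds it holds the second highest number: compound 3, `NC(=O)[C@@H](CCC(F)(F)F)N(C[C@H]1CCCO1)S(=O)(=O)c1ccc(Cl)cc1`, gives 19.1 10^-6 cm/s, and compound 2, `NC(=O)[C@@H](CCC(F)(F)F)N(CC1CCCC1)S(=O)(=O)c1ccc(Cl)cc1`, gives 6.01 10^-6 cm/s. The step from compound 1 to compound 3 was a 1.1-fold higher number from compound 1 to compound 3 (0.02 log units; within the scatter), whereas the step of a 3.0-fold lower number from compound 1 to compound 2 (0.48 log units; beyond the scatter) ran clearly downward.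

Compound 4, `NC(=O)[C@@H](CCC(F)(F)F)N(C[C@H]1CCO1)S(=O)(=O)c1ccc(Cl)cc1`, differs from compound 1 in one place: oxetan-2-yl in place of 4,4-dimethyloxetan-2-yl on a saturated chain carbon bound to a sulfonamide nitrogen. Within the data shown here, the closest precedent is a 1.1-fold higher number from compound 1 to compound 3 (0.02 log units; within the scatter), where one small ring bearing an oxygen replaced another and the number barely moved; only the all-carbon ring of compound 2 brought a step beyond the scatter. For compound 4 in this assay a step of a 1.2-fold lower number from compound 1 to compound 4 (0.08 log units; within the scatter) is therefore expected, so compound 4 is estimated at 15 10^-6 cm/s, with a range of 8 10^-6 cm/s to 28 10^-6 cm/s.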

Compound 4, apparent permeability: 28.7 10^-6 cm/s
For compound 4 the middle estimate is 1.9-fold (0.28 log units) below the measured one; measured number outside the range, above it.
By their numbers in this assay, from the lowest: compound 2; then compounds 1, 3 and 4 (each within the scatter of the next).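

In this assay, losing the dimethyl substitution from the four-membered ring leaves the number within the scatter (a 1.6-fold higher number from compound 1 to compound 4 (0.20 log units; within the scatter)), and so does shrinking the oxygen ring from oxolan-2-yl to oxetan-2-yl (a 1.5-fold higher number from compound 3 to compound 4 (0.18 log units; within the scatter)). The three oxygen-bearing rings at this position therefore cannot be told apart, while the all-carbon cyclopentyl stays clearly separate (a 4.8-fold higher number from compound 2 to compound 4 (0.68 log units; beyond the scatter)). No measurement shown here explains this gap between compound 2 and the oxygen-bearing rings. Going by these compounds, whether an open methoxyethyl chain or a nitrogen ring such as pyrrolidine would match compound 4 or compound 2 remains open.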